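Removing the Methyl from Compound 3's Core

The source may hold more compounds than are shown below. What is called first, only, known or untested is meant among the compounds shown, and "the series" means these compounds.

The measured compounds:
compound 1, `Cc1ccc2cnc(-c3cccc(C#N)c3)nc2n1`, 240 nM in a functional assay on CHO cells for antagonist activity at metabotropic glutamate receptor 5 (Rattus norvegicus), read by FLIPR and calcium flux; a higher number here means a weaker inhibitor, a lower number a stronger inhibitor
compound 2, `Cc1ccc2cnc(-c3cccc(S(C)(=O)=O)c3)nc2n1`, a limit of this assay, > 30000 nM
compound 3, `Cc1ccc2cnc(-c3cccc(Br)c3)nc2n1`, 38 nM

Compound 3 gives the lowest number of the two that are numbers; compound 1 stands nearest, a 6.3-fold lower number from compound 1 to compound 3 (0.80 log units; beyond the scatter). The value of compound 2 is a limit of this assay the limit of > 30000 nM in this assay, at which 1 of the 3 values shown sits, and not a number.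

Compound 4, `Brc1cccc(-c2ncc3cccnc3n2)c1`, differs from compound 3 only in the core: hydrogen in place of methyl on an aromatic carbon. Among the measured compounds shown here, none of the measured steps touches this position; all three, an at least 120-fold higher number from compound 1 to compound 2 (2.09 log units; beyond the scatter), a 6.3-fold lower number from compound 1 to compound 3 (0.80 log units; beyond the scatter) and an at least 780-fold lower number from compound 2 to compound 3 (2.89 log units; beyond the scatter), change the group on the pendant ring while the methyl stays in place. The data therefore give no direct guide to the size of the step. With no evidence either way, the step from compound 3 to compound 4 is expected to be small, a 1.8-fold higher number from compound 3 to compound 4 (0.27 log units; within the scatter), most likely within the scatter. Compound 4 is estimated at 70 nM in this assay, with a range of 20 nM to 300 nM.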

Compound 4, half-maximal inhibitory concentration: 333 nM
Estimate against measurement, compound 4: 4.8-fold (0.68 log units) below; measured number outside the range, above it.
By their numbers in this assay, from the lowest: compound 3; then compounds 1 and 4 (each within the scatter of the next). At a limit, above all of these: compound 2.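

In this assay, the change of methyl to hydrogen on the aromatic carbon next to the ring nitrogen gives an 8.8-fold higher number from compound 3 to compound 4 (0.94 log units; beyond the scatter). Among the compounds shown here, the earlier steps all changed the group on the pendant ring, so this is the first sign that the core position also matters, and here a single carbon leaving the methyl position is enough to move the number beyond the scatter. Nothing measured here explains this step.

The compounds shown leave open whether the methyl counts for as much with cyano on the pendant ring as it does with bromo, since this one pair carries bromo alone. They also leave open how an ethyl, a methoxy or an amine on that same carbon would compare with methyl.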